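From Hydroxy to Methoxy on Compound 1

The source may report more compounds than this note shows. Statements on the series, on what has been measured and on what is new or still open speak of the compounds shown alone.

Compound 1 `O=C(CCCc1nc2ccccc2c(=O)[nH]1)N/N=C/c1cc(O)c(O)c(O)c1` gives 40000000 nM
Compound 2 `COc1cc(/C=N/NC(=O)CCCc2nc3ccccc3c(=O)[nH]2)cc(OC)c1OC` gives 60000000 nM
Compound 3 `O=C(CCc1nc2ccccc2c(=O)[nH]1)N/N=C/c1ccc(Cl)cc1` gives 185000000 nM

All three were tested in a physicochemical assay, read by spectrophotometry, with a stated time of 6 min; on this read-out higher numbers stand for weaker inhibition and lower numbers for stronger inhibition. Compound 1 stands level with compound 2 within the usual scatter, while compound 3 has a clearly higher number, meaning weaker inhibition.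

Compound 4 `COc1cc(/C=N/NC(=O)CCCc2nc3ccccc3c(=O)[nH]2)cc(O)c1O` differs from compound 1 in one place: methyl in place of hydrogen on an oxygen on an aromatic ring. This puts methyl in place of hydrogen on an oxygen on an aromatic ring, turning hydroxy to methoxy. For the measured compounds named here, no measured pair shows this single change, so the evidence is thin. The nearest measured value to that of compound 1 is compound 2 at 60000000 nM, so no step beyond the scatter is expected in this assay. The estimated step is a 1.3-fold higher number from compound 1 to compound 4 (0.10 log units; within the scatter), which would stay within the scatter. Compound 4 is expected at 50000000 nM, with an estimated range of 25000000 nM to 100000000 nM.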

Compound 4, half-maximal inhibitory concentration: 50000000 nM
Beside the measured number, compound 4's estimate shows no gap at the digits printed; measured number inside the range.
By their numbers in this assay, from the lowest: compounds 1, 4 and 2 (each within the scatter of the next); then compound 3.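

Putting methyl in place of hydrogen on an oxygen on an aromatic ring gives a 1.3-fold higher number from compound 1 to compound 4 (0.10 log units; within the scatter) in this assay. For the compounds shown here, this is the first direct reading of a single change, and it shows that hydroxy to methoxy at this position leaves compound 1 and compound 4 level. Nothing available explains why this change has so little effect.

The compounds shown leave open whether an amine or a longer chain on that oxygen would also stay level. They also leave open whether the same change reads alike on the other ring oxygens when made one at a time.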